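The source may hold more compounds than are shown below. What is called first, only, known or untested is meant among the compounds shown, and "the series" means these compounds.

Compound 1, `Cc1nc(N)sc1CCCN/C(N)=N/C(=O)NC(C)c1ccc(Cl)cc1`, gives 24.6 nM in a functional assay on Right cardiac atrium for agonist activity at histamine H2 receptor (Cavia porcellus), with a stated time of 30 min, in the presence of a further agent that is not named here; a lower number here means that less compound is needed, a higher number that more compound is needed for the effect.
Compound 2, `Cc1nc(N)sc1CCCN/C(N)=N/C(=O)NC(C)c1ccc(OC(F)(F)F)cc1`, gives 724 nM in the same assay.

Going by the values given here, of these two numbers, compound 2 stands highest; its nearest neighbour is compound 1, and the gap between them is beyond the usual scatter, as the single measured step shows: a 29-fold higher number from compound 1 to compound 2 (1.47 log units; beyond the scatter).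

Compound 3, `Cc1nc(N)sc1CCCN/C(N)=N/C(=O)NC(C)c1ccc(F)cc1`, has not yet been measured. It differs from compound 2 in one place: fluoro in place of trifluoromethoxy on an aromatic carbon. Among the compounds with values here, only the step from compound 1 to compound 2 bears on this change, since it concerns the same position and swaps one single-atom group for trifluoromethoxy. That step was large and went upward. Compound 3 reverses the trifluoromethoxy and puts a single atom, fluoro, in its place, so a large step in the opposite direction is expected, back toward the number of compound 1. Whether fluoro matches chloro exactly cannot be said from these data, so the range is kept wide. Compound 3 is therefore expected to give 50 nM, between 15 nM and 200 nM, an estimated 14-fold lower number from compound 2 to compound 3 (1.16 log units; beyond the scatter).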

Compound 3, half-maximal effective concentration: 23.4 nM
Beside the measured number, compound 3's estimate is 2.1-fold (0.33 log units) above it; the measured number falls inside the stated range.
By their numbers in this assay, from the lowest: compounds 3 and 1 (each within the scatter of the next); then compound 2.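

In this assay fluoro in place of trifluoromethoxy gives a 31-fold lower number from compound 2 to compound 3 (1.49 log units; beyond the scatter) and so the high number of compound 2 is now seen from a second side, matching in size what a 29-fold higher number from compound 1 to compound 2 (1.47 log units; beyond the scatter) showed going the other way. Fluoro in place of chloro gives only a 1.1-fold lower number from compound 1 to compound 3 (0.02 log units; within the scatter) so on this aromatic carbon, para to a large group, these two groups cannot be told apart by this read-out. Across these three compounds, then, what moves the number is the presence or absence of trifluoromethoxy, with its 5 heavy atoms, and not the exchange of one halogen for the other.

Still open, going by these compounds, is whether the high number belongs to trifluoromethoxy alone or would also appear with a methoxy group, a trifluoromethyl group, a methyl group or plain hydrogen on the same carbon. Nothing available here explains why trifluoromethoxy stands apart from fluoro and chloro.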